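Anilide variations on a shared quinazoline-free core series

A few compounds are considered here, and "the series" means these few. Any claim that something is new, unique, unknown or untested is made for them only; others in the source may bear on it.

Measured compounds:
compound 1, `O=C(CSc1nc(Nc2ccccc2)c2ccccc2n1)Nc1ccccc1Cl`, 9610 nM
compound 2, `O=C(CSc1nc(Nc2ccccc2)c2ccccc2n1)Nc1cccc(F)c1`, 6790 nM
compound 3, `O=C(CSc1nc(Nc2ccccc2)c2ccccc2n1)Nc1cccc([N+](=O)[O-])c1`, 17900 nM

Three anilides of the shared core have been tested in a functional assay on NCI-H1975 cells (Homo sapiens) for inhibition, read by MTT assay, with a stated time of 72 h; on this read-out lower numbers stand for stronger inhibition and higher numbers for weaker inhibition. Compound 2 sits at the low end of the three numbers: the gap to compound 1, a 1.4-fold lower number from compound 1 to compound 2 (0.15 log units; within the scatter), is within the scatter, so no order between those two is claimed, while compound 3 lies clearly apart, a 2.6-fold higher number from compound 2 to compound 3 (0.42 log units; beyond the scatter). From compound 1 to compound 3 the change is a 1.9-fold higher number from compound 1 to compound 3 (0.27 log units; within the scatter).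

Compound 4, `O=C(CSc1nc(Nc2ccccc2)c2ccccc2n1)Nc1ccc([N+](=O)[O-])cc1`, has not yet been measured in this assay. It differs from compound 2 by 4-nitrophenyl in place of 3-fluorophenyl on an amide-type nitrogen. Within the data shown here, the one measured step that bears on it is the nitro in place of fluoro step from compound 2 to compound 3, a 2.6-fold higher number from compound 2 to compound 3 (0.42 log units; beyond the scatter), a modest rise in the number; the step from compound 1 to compound 3 points the same way. For compound 4 a modest rise of similar size is therefore expected, a 2.2-fold higher number from compound 2 to compound 4 (0.34 log units; beyond the scatter), with the estimate for compound 4 put at 15000 nM, between 7000 nM and 32000 nM.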

Compound 4, half-maximal inhibitory concentration: 13000 nM
Beside the measured number, compound 4's estimate is 1.2-fold (0.06 log units) above it; the measured number falls inside the stated range.
By their numbers in this assay, from the lowest: compounds 2, 1, 4 and 3 (each within the scatter of the next, the first and the last beyond it).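

In this assay the 4-nitrophenyl and 3-nitrophenyl groups on the amide-type nitrogen cannot be told apart, with a 1.4-fold lower number from compound 3 to compound 4 (0.14 log units; within the scatter), so the two nitro placements shown give no readable difference. The other new steps, a 1.9-fold higher number from compound 2 to compound 4 (0.28 log units; within the scatter) and a 1.4-fold higher number from compound 1 to compound 4 (0.13 log units; within the scatter), also lie within the scatter, which leaves a 2.6-fold higher number from compound 2 to compound 3 (0.42 log units; beyond the scatter) as the only step among these anilides beyond it. Nothing available on these compounds bears on what lies behind these small differences.

The phenyl substituents shown are only chloro, fluoro and nitro, so it remains open whether an amine or a carboxylic acid on that ring would give a step clearly beyond the scatter. Also open, as far as these compounds go, is how a longer chain on the amide-type nitrogen would read, and every change to the rest of the shared core.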